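Series notes: sulfo-chain analogues; demethylation at the bridging nitrogen

A few compounds are considered here, and "the series" means these few. Any claim that something is new, unique, unknown or untested is made for them only; others in the source may bear on it.

Measured so far:
compound 1 `CN(Cc1cnc2nc(N)nc(N)c2n1)c1ccc(C(=O)NC(CCS(=O)(=O)O)C(=O)O)cc1` gives 0.041 uM
compound 2 `CN(Cc1cnc2nc(N)nc(N)c2n1)c1ccc(C(=O)NC(CS(=O)(=O)O)C(=O)O)cc1` gives 0.045 uM

Both measurements come from a functional assay for inhibition of Dihydrofolate reductase (Mus musculus); on this read-out higher numbers stand for weaker inhibition and lower numbers for stronger inhibition. Compound 1 holds the lowest of the two numbers, with compound 2 nearest to it; the step of a 1.1-fold higher number from compound 1 to compound 2 (0.04 log units; within the scatter) is within the scatter, so the two compounds cannot be ranked against each other. Among the compounds with values here, what this pair shows is only that the exchange on the sulfo-bearing chain leaves this assay unchanged.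

Compound 3 `Nc1nc(N)c2nc(CNc3ccc(C(=O)NC(CCS(=O)(=O)O)C(=O)O)cc3)cnc2n1` has not yet been measured. It differs from compound 1 by hydrogen in place of methyl on a nitrogen on an aromatic ring. Within the data shown here, no measured step touches this nitrogen: the single step available, from compound 1 to compound 2, concerns the chain on the other end of the molecule and gives no guidance on the methyl here. In the absence of a bearing step the working expectation for compound 3 is a step near zero, with the estimate a 1.5-fold higher number from compound 1 to compound 3 (0.17 log units; within the scatter) not expected to exceed the scatter in either direction. Compound 3 is therefore expected to give about 0.06 uM, within a range of 0.02 uM to 0.18 uM.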

Compound 3, concentration for 50% inhibition: 0.063 uM
Beside the measured number, compound 3's estimate is 1.1-fold (0.02 log units) below it; measured number inside the range.
By their numbers in this assay, from the lowest: compounds 1, 2 and 3 (each within the scatter of the next).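

In this assay, within the data shown here, the nitrogen on an aromatic ring is now probed for the first time, and the step of a 1.5-fold higher number from compound 1 to compound 3 (0.19 log units; within the scatter) for hydrogen in place of methyl stays within the scatter, so compound 3 cannot be ranked against compound 1. The earlier pair covered only the exchange on the sulfo-bearing chain, whereas this step shows that, with the chain of compound 1 held fixed, removing the methyl from this nitrogen brings no change that can be told apart from repeat variation, so the methyl is not required to keep the read-out at this level. Nothing measured here offers an explanation for this result.

The two substituents at this nitrogen, hydrogen and methyl, leave open whether a larger group such as ethyl, or an acyl group such as acetyl, would also leave the read-out unchanged. Also open, on these data alone, is whether the same exchange would give a similarly small step on the chain of compound 2, and whether a carboxylic acid in place of the sulfo group would hold the read-out on either chain.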